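Isopentyloxy in place of neopentyloxy on the ether chain

This account rests on a few compounds, and the source may have more. Where it says the series, first, only, none or still open, it means among the compounds named here.

Measured so far:
compound 1 `CC1CCN(c2cc(C(C)(C)C)ccc2CNC(=O)C(C)c2ccc(NS(C)(=O)=O)c(F)c2)CC1`: 0.7 nM
compound 2 `CC(C(=O)NCc1ccc(C(C)(C)C)cc1OCC(C)(C)C)c1ccc(NS(C)(=O)=O)c(F)c1`: 3.8 nM

Both compounds were tested in an assay on cells for antagonist activity at transient receptor potential cation channel subfamily V member 1 (Homo sapiens), read by FLIPR and calcium flux, with a stated time of 6 min; on this read-out higher numbers stand for weaker inhibition and lower numbers for stronger inhibition. On the two numbers available, compound 2 gives the higher reading, 3.8 nM, and its nearest neighbour is compound 1, reached by a 5.4-fold higher number from compound 1 to compound 2 (0.73 log units; beyond the scatter), a change of the side group on an aromatic carbon.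

Compound 3 `CC(C)CCOc1cc(C(C)(C)C)ccc1CNC(=O)C(C)c1ccc(NS(C)(=O)=O)c(F)c1` has not been measured. Its difference from compound 2 is isobutyl in place of tert-butyl on a saturated chain carbon bound to an oxygen on an aromatic ring. The chain keeps its length and its oxygen; only its branching is rearranged, so the ether side group goes from neopentyloxy to isopentyloxy.

Within the data shown here, no measured step touches this kind of change. Among the measured compounds shown here, the only step available, a 5.4-fold higher number from compound 1 to compound 2 (0.73 log units; beyond the scatter), swaps a ring-bearing nitrogen group for the ether chain itself and says nothing about how that chain may be branched. With no evidence pointing either way, the expected outcome for compound 3 is a 1.1-fold higher number from compound 2 to compound 3 (0.02 log units; within the scatter), that is, no step beyond the scatter.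

Compound 3 is therefore estimated at 4 nM in this assay, with a range from 1.3 nM to 12 nM.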

Compound 3, inhibition constant: 0.6 nM
Estimate against measurement, compound 3: 6.7-fold (0.82 log units) above; the measured number lies below the stated range.
By their numbers in this assay, from the lowest: compounds 3 and 1 (each within the scatter of the next); then compound 2.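

In this assay, shifting the branch along the ether chain gives a 6.3-fold lower number from compound 2 to compound 3 (0.80 log units; beyond the scatter) even though the two compounds hold the same atoms, so at this position the arrangement of the chain matters and not just its size. Among these compounds, the earlier step showed only that one side group could be exchanged for a very different one, and it left the impression that an ether chain reads worse than the 4-methylpiperidin-1-yl group; the new comparison, a 1.2-fold lower number from compound 1 to compound 3 (0.07 log units; within the scatter), removes that impression, since the two groups cannot be told apart here and the higher reading of compound 2 belongs to neopentyloxy rather than to every ether chain. No measurement shown here explains why moving the branch has an effect of this size.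

Still open, on these data alone, is whether an unbranched pentyloxy chain, or a longer one such as hexyloxy, would read like compound 3 or like compound 2. Also open, as far as these compounds go, is whether a ring at the end of the chain, as in cyclopentylmethoxy, would fit the same pattern.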